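A few compounds are considered here, and "the series" means these few. Any claim that something is new, unique, unknown or untested is made for them only; others in the source may bear on it.

Compound 1 `CCN1CCN(CCCn2cnc3c(N4CCN(C(=O)C5CCCC5)CC4)nc(NCc4ccc(OC)cc4)nc32)CC1` carries a cyclopentylcarbonyl group on an amine nitrogen in a ring. In an assay on HEK293 cells for antagonist activity at Toll-like receptor 9 (Homo sapiens), read by spectrophotometry (on this read-out higher numbers stand for weaker inhibition and lower numbers for stronger inhibition), compound 1 gives only a limit, > 30000 nM, so no number is known for it; it sits at the limit of > 30000 nM in this assay, at which 1 of the 3 values shown sits. Two companions replace that group. Compound 2 `CCN1CCN(CCCn2cnc3c(N4CCN(C5CCCC5)CC4)nc(NCc4ccc(OC)cc4)nc32)CC1` gives 120 nM in this assay, a step of an at least 250-fold lower number from compound 1 to compound 2 (2.39 log units; beyond the scatter). Compound 3 `CCN1CCN(CCCn2cnc3c(N4CCN(CC)CC4)nc(NCc4ccc(OC)cc4)nc32)CC1` gives 200 nM, a step of an at least 150-fold lower number from compound 1 to compound 3 (2.17 log units; beyond the scatter). Between those two the step is a 1.7-fold higher number from compound 2 to compound 3 (0.22 log units; within the scatter). Compound 4 `CCN1CCN(CCCn2cnc3c(N4CCN(C(=O)C5CCCC5)CC4)nc(NCc4ccc(F)cc4)nc32)CC1` keeps the cyclopentylcarbonyl group and differs from compound 1 in one place: fluoro in place of methoxy on an aromatic carbon. Within the data shown here, none of the measured steps touches that change; every one of them alters the group on the amine nitrogen in a ring while the methoxy stays in place. The measured steps therefore give no guide here, and what remains is that compound 1 sits at the limit. The step is expected to be a number no higher from compound 1 to compound 4 (the limit leaves the size open). Compound 4 is accordingly estimated at 30000 nM, with a range from 8000 nM to 100000 nM, and is expected most likely to be reported again only as a limit.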

Compound 4, half-maximal inhibitory concentration: > 30000 nM
Compound 4 gave a limit, no number (the forecaster's own chance of this, stated with the estimate: 70%); the middle value lies on the limit itself.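

In this assay, among these compounds, compound 1 and compound 4 are each reported only as a limit, so no step between them can be read. It stays open whether fluoro in place of methoxy changes inhibition at all, as both compounds rest at the same limit: the limit of > 30000 nM in this assay, at which 2 of the 4 values shown sit.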